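Swapping an isobutyl arm for a methoxybenzyl one

This account rests on a few compounds, and the source may have more. Where it says the series, first, only, none or still open, it means among the compounds named here.

Of the compounds shown here, three sharing one core have been measured in an assay on isolated protein for inhibition of aldehyde dehydrogenase 1A1 (Homo sapiens), read by spectrophotometry, tested at 10 uM; on this read-out lower numbers stand for less inhibition and higher numbers for more inhibition at the one concentration tested (going by the name of the read-out). Compound 1 `Cc1cccc(Cn2c(CN3CCN(C(=O)C4CCCCC4)CC3)nc3ccccc32)c1` gives 31.9%, compound 3 `Cc1cccc(Cn2c(CN3CCN(C(=O)c4ccc(Cl)cc4)CC3)nc3ccccc32)c1` gives 23.2%, and compound 2 `CC(C)Cn1c(CN2CCN(C(=O)C3CC3)CC2)nc2ccccc21` gives 13.1%. Compound 2 stands lowest of the three, separated from compound 3 and from compound 1 by gaps that fall beyond the scatter of this read-out.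

The next compound, compound 4 `COc1cccc(Cn2c(CN3CCN(C(=O)C4CC4)CC3)nc3ccccc32)c1`, differs from compound 2 in one place: 3-methoxyphenyl in place of isopropyl on a saturated chain carbon bound to an aromatic nitrogen. Within the data shown here, the only measured step, a number 8.7 percentage points lower from compound 1 to compound 3 (within the scatter), concerns a change on a carbonyl carbon at the far end of the molecule and is within the scatter, so no measured step bears directly on the change from compound 2 to compound 4. What can be said is that compound 1 and compound 3, which both carry a benzyl-type arm rather than isobutyl at this position, sit higher than compound 2, though each also differs from compound 2 on the carbonyl carbon, so the comparison is not clean.

On that basis the step of a number 9.9 percentage points higher from compound 2 to compound 4 (within the scatter) is expected to be a modest rise, with wide uncertainty. Compound 4 is estimated at 23%, between 10% and 36%.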

Compound 4, a percentage reported as inhibition, at one concentration (the size of the read-out at that concentration, not a potency): 44.4%
Estimate against measurement, compound 4: 21.4 percentage points below, and the stated range ends below it.
By their numbers in this assay, from the lowest: compound 2; then compounds 3 and 1 (each within the scatter of the next); then compound 4.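

In this assay, replacing isobutyl with 3-methoxybenzyl gives a number 31.3 percentage points higher from compound 2 to compound 4 (beyond the scatter), and the rest of the molecule stays the same, so this is a clean reading of a change on the saturated chain carbon bound to an aromatic nitrogen. Among these compounds, the only other step available, a number 8.7 percentage points lower from compound 1 to compound 3 (within the scatter), concerns the carbonyl carbon, so the new step is the first to show that a single change can move this read-out by more than the usual scatter, and it does so at a different place in the molecule. Nothing measured here explains why the number rises with this change.

The swap brings in a six-membered aromatic ring and a methoxy oxygen together, so these compounds leave open how much of the rise belongs to the ring and how much to the methoxy group. A plain benzyl arm would separate the two if placed on the otherwise unchanged molecule, and a longer chain such as n-hexyl would test whether a larger arm without a ring has a similar effect.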